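The compounds below may be only part of what the source reports. "The series", "measured", "known", "first", "only" and "open" are said of these compounds alone.

Working notes on the series.

Compound 1 `S=C(N/N=C1\CC2(CCCCC2)Oc2c1ccc1ccccc21)N1CCNCC1` and compound 2 `Cc1ccc(NC(=O)N/N=C2\CC3(CCCCC3)Oc3c2ccc2ccccc32)cc1` share the same core and differ only in the group on the amine nitrogen of the hydrazone side chain. In a functional assay on MCF7 cells (Homo sapiens) for antiproliferative activity, read by MTT assay, with a stated time of 96 h (a higher number here means a weaker inhibitor, a lower number a stronger inhibitor), compound 1 gives 14200 nM, and compound 2 gives 9070 nM. Within the data shown here, the step is a 1.6-fold lower number from compound 1 to compound 2 (0.19 log units; within the scatter), so the two numbers are not distinguishable; compound 1 carries the highest number of the two, with compound 2 its only neighbour.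

Compound 3 `N/N=C1\CC2(CCCCC2)Oc2c1ccc1ccccc21` is not yet measured. Relative to compound 1 the change is a hydrogen atom in place of a group of 8 heavy atoms (5 carbon, 2 nitrogen, 1 sulfur; one six-membered non-aromatic ring with 2 hetero atoms), on an amine nitrogen. Among the measured compounds shown here, of the measured steps only the one from compound 1 to compound 2 bears on this position, and it exchanged one group for another of similar size rather than removing the group altogether; it was within the scatter. For the measured compounds named here, no measured step shows what the bare hydrogen does here, so the expectation rests on the two numbers alone and is weakly held. The working expectation is a step of a 1.5-fold higher number from compound 1 to compound 3 (0.19 log units; within the scatter), with compound 3 estimated at 22000 nM, in a range from 7000 nM to 70000 nM.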

Compound 3, half-maximal inhibitory concentration: 9740 nM
Beside the measured number, compound 3's estimate is 2.3-fold (0.35 log units) above it; the range from low to high includes it.
By their numbers in this assay, from the lowest: compounds 2, 3 and 1 (each within the scatter of the next).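

Compound 3 shows what the bare hydrogen does on this amine nitrogen in this assay: removing the whole group gives a 1.5-fold lower number from compound 1 to compound 3 (0.16 log units; within the scatter) and the hydrogen in place of (4-methylphenyl)carbamoyl gives a 1.1-fold higher number from compound 2 to compound 3 (0.03 log units; within the scatter) in the same series. The earlier pair only exchanged one group for another, whereas these steps show that neither group on this nitrogen is set apart from hydrogen by the numbers, so the three compounds cannot be ordered and no contribution from either group can be read here. No data shown bear on why the numbers stand together.

On these data alone, whether any group on this amine nitrogen can carry the number beyond the scatter stays open, as does whether the values near the shared core reflect the core alone or something else. An acetyl group, a short alkyl chain or a carboxylic acid at this place would test the first question, and a change to the core of compound 3 with the hydrogen kept would test the second.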